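Swapping the oxazole-side group: from fluorinated ketone to pyridine

The source may hold more compounds than are shown below. What is called first, only, known or untested is meant among the compounds shown, and "the series" means these compounds.

Measured compounds:
- compound 1 `Cc1coc(C(=O)CCCCCCc2ccccc2)n1`: 520 nM
- compound 2 `CC(=O)c1coc(C(=O)CCCCCCc2ccccc2)n1`: 2 nM
- compound 3 `O=C(CCCCCCc1ccccc1)c1nc(C(=O)C(F)(F)F)co1`: 470 nM

All three share a core carrying a long phenyl-tipped chain, and differ only in the group on an aromatic carbon of the five-membered ring. In an assay on isolated protein for inhibition of Fatty-acid amide hydrolase 1 (Rattus norvegicus) (a lower number here means a stronger inhibitor, a higher number a weaker inhibitor), compound 3 stands second highest of the three numbers; its nearest neighbour is compound 1, within the scatter, and its furthest is compound 2, as a 240-fold higher number from compound 2 to compound 3 (2.37 log units; beyond the scatter) shows. For the measured compounds named here, the steps that bear on this position are a 260-fold lower number from compound 1 to compound 2 (2.41 log units; beyond the scatter) and a 1.1-fold lower number from compound 1 to compound 3 (0.04 log units; within the scatter): an acetyl brings a large gain, while a (trifluoromethyl)carbonyl brings none.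

Compound 4 `O=C(CCCCCCc1ccccc1)c1nc(-c2ccncc2)co1` changes this position again: pyridin-4-yl in place of (trifluoromethyl)carbonyl on an aromatic carbon. No measured compound carries an aromatic ring there, so the effect of a pyridin-4-yl is not covered by any step shown. The range seen for this position is wide, as a 260-fold lower number from compound 1 to compound 2 (2.41 log units; beyond the scatter) shows, and a new group could land anywhere within it. A moderate lower number is expected, with wide uncertainty; the expected step is a 7.8-fold lower number from compound 3 to compound 4 (0.89 log units; beyond the scatter). Compound 4 is estimated at 60 nM, between 5 nM and 700 nM.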

Compound 4, inhibition constant: 1.6 nM
Compound 4: middle estimate off by 38-fold (1.57 log units), on the high side; measured number below the stated range.
By their numbers in this assay, from the lowest: compounds 4 and 2 (each within the scatter of the next); then compounds 3 and 1 (each within the scatter of the next).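

In this assay this position turns out to accept an aromatic ring: the pyridin-4-yl gives a 290-fold lower number from compound 3 to compound 4 (2.47 log units; beyond the scatter) and a 330-fold lower number from compound 1 to compound 4 (2.51 log units; beyond the scatter), so a group here needs no carbonyl to reach the low numbers. Acetyl and pyridin-4-yl, though very different groups, cannot be told apart, with a 1.3-fold lower number from compound 2 to compound 4 (0.10 log units; within the scatter) lying within the scatter. The (trifluoromethyl)carbonyl and the pyridin-4-yl have the same number of heavy atoms and the same number of hydrogen-bond acceptors, so these simple counts do not separate them, and no measurement on hand explains the large gap between them.

Still open, from the compounds shown here alone, is whether the ring nitrogen of the pyridin-4-yl matters, a question that a plain phenyl or a pyridin-3-yl in the same place would help to answer. The compounds shown also leave open how an amine or a carboxylic acid would fare at this position, and whether the low numbers of compound 2 and compound 4 would hold with a shorter or longer chain on the shared core.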